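The compounds below may be only part of what the source reports. "The series", "measured", "known", "first", "only" and "open" are said of these compounds alone.

Compound 1 `COc1cc(C(=N)NC(C)C)ccc1-c1cc2cc(C(=N)NC(C)C)ccc2o1` and compound 2 `CC(C)NC(=N)c1ccc(-c2cc3cc(C(=N)NC(C)C)ccc3o2)c(O)c1` share one core and differ by hydrogen in place of methyl on an oxygen on an aromatic ring. In an ADME assay on L6 cells (Rattus norvegicus) for cytotoxicity (on this read-out higher numbers stand for weaker inhibition and lower numbers for stronger inhibition), compound 1 gives 98100 nM. For compound 2 the assay reports only a limit in this assay, > 183000 nM, not a resolved number. The change thus reads as an at least 1.8-fold higher number from compound 1 to compound 2 (0.27 log units; that floor lies within the scatter), and that floor rests on (the limit of > 183000 nM in this assay, at which 1 of the 3 values shown sits).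

Compound 3 `COc1cc(C(=N)N)ccc1-c1cc2ccc(C(=N)N)cc2o1` carries a different core; the difference between the two cores is not broken down here. In this assay compound 3 gives 108000 nM, and next to compound 1 the two values sit close together.

Compound 4 `N=C(N)c1ccc(-c2cc3ccc(C(=N)N)cc3o2)c(O)c1` has not yet been measured in this assay. It differs from compound 3 by hydrogen in place of methyl on an oxygen on an aromatic ring, the same change at the same kind of place as between compound 1 and compound 2. For the measured compounds named here, with that single measured step as the only guide, an expected shift of a 1.9-fold higher number from compound 3 to compound 4 (0.27 log units; within the scatter) follows. Compound 4 is therefore expected to give about 200000 nM, between 120000 nM and 350000 nM, with a real chance that only a limit is reported.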

Compound 4, half-maximal inhibitory concentration: > 221000 nM
Compound 4 was reported as a limit; the forecaster's own chance of this, stated with the estimate: 55%; at least 1.1-fold (0.04 log units) between middle value and limit.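

In this assay compound 4 is reported only as a limit, > 221000 nM. Methoxy to hydroxy on this core gives an at least 2.0-fold higher number from compound 3 to compound 4 (0.31 log units; beyond the scatter), and set beside the same change on the other core, the two steps read: the same change on two cores in this assay, an at least 1.8-fold higher number (0.27 log units; that floor lies within the scatter) from compound 1 to compound 2 and an at least 2.0-fold higher number (0.31 log units; beyond the scatter) from compound 3 to compound 4; the limit leaves it open whether they differ. For the compounds shown here, the number rises on both cores, which fits the change carrying over from one to the other, but only the step on the core of compound 3 clears the scatter, and with compound 2 and compound 4 both reported as limits, the true size of the change remains unknown on either core.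

The compounds shown leave open how a longer chain on that oxygen, such as ethyl, or an amine in place of the hydroxy would read in this assay. They also leave open whether the change would behave the same way on any core beyond these two.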